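The source may hold more compounds than are shown below. What is called first, only, known or untested is meant among the compounds shown, and "the series" means these compounds.

Measured so far in an assay on isolated protein for inhibition of proto-oncogene tyrosine-protein kinase receptor Ret variant V804L (Homo sapiens), read by 33P incorporation, with stated times of 15 min and 40 min; on this read-out higher numbers stand for weaker inhibition and lower numbers for stronger inhibition:
compound 1 `COc1ccc(NC(=O)Nc2ccc(Nc3ncnc4c3OCCN4)cc2)cc1` — 1220 nM
compound 2 `COc1cccc(NC(=O)Nc2ccc(Nc3ncnc4c3OCCN4)cc2)c1` — > 10000 nM, a limit of the assay rather than a number

Compound 1 carries the only number shown; the other value is a limit (the limit of > 10000 nM in this assay, at which 1 of the 2 values shown sits). The change to compound 3 `O=C(Nc1ccc(Nc2ncnc3c2OCCN3)cc1)Nc1cccc2ccccc12` is naphthalen-1-yl in place of 4-methoxyphenyl on an amide-type nitrogen. For the measured compounds named here, the one measured step at that nitrogen, an at least 8.1-fold higher number from compound 1 to compound 2 (0.91 log units; beyond the scatter), went toward weaker inhibition. A modest loss is therefore expected, a 2.5-fold higher number from compound 1 to compound 3 (0.39 log units; beyond the scatter), with a real chance of only a limit. Compound 3 is estimated at 3000 nM, range 800 nM to 10000 nM.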

Compound 3, half-maximal inhibitory concentration: > 10000 nM
Compound 3 ended at the assay's limit; the forecaster's own chance of this, stated with the estimate: 25%; at least 3.3-fold (0.52 log units) between middle value and limit.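

Naphthalen-1-yl in place of 4-methoxyphenyl on the amide-type nitrogen gives an at least 8.1-fold higher number from compound 1 to compound 3 (0.91 log units; beyond the scatter), the second change at this nitrogen to end at a limit. Compound 1 remains the only one of the three with a number in this assay, and the other two values are limits: the limit of > 10000 nM in this assay, at which 2 of the 3 values shown sit. The step from compound 2 to compound 3 cannot be read, so 3-methoxyphenyl and naphthalen-1-yl cannot be ranked.

Open, on these data alone, is whether any group on this nitrogen gives stronger inhibition than 4-methoxyphenyl. Also open, as far as these compounds go, is whether an amine or a carboxylic acid in place of the methoxy group keeps inhibition.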